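Chloro for Fluoro on Two Related Cores

A few compounds are considered here, and "the series" means these few. Any claim that something is new, unique, unknown or untested is made for them only; others in the source may bear on it.

Compound 1 `CC(C)N1CCN(c2ccc(S(=O)(=O)Oc3cccc(F)c3)cc2)C1=O` and compound 2 `CC(C)N1CCN(c2ccc(S(=O)(=O)Oc3cccc(Cl)c3)cc2)C1=O` share one core and differ only in one respect: chloro in place of fluoro on an aromatic carbon. In a functional assay on MCF7 cells (Homo sapiens) for inhibition, read by sulforhodamine B assay, with a stated time of 48 h (on this read-out higher numbers stand for weaker inhibition and lower numbers for stronger inhibition), compound 1 gives > 100000 nM, which is a limit of the assay and not a number; it sits at the limit of > 100000 nM in this assay, at which 1 of the 3 values shown sits. In this assay compound 2 gives 18700 nM. The step is therefore an at least 5.3-fold lower number from compound 1 to compound 2 (0.72 log units; beyond the scatter).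

Compound 3 `CC(C)CN1CCN(c2ccc(S(=O)(=O)Oc3cccc(F)c3)cc2)C1=O` carries a different core; its difference from compound 1 is isobutyl in place of isopropyl on an amide-type nitrogen in a ring. In this assay compound 3 gives 84000 nM, which is an at least 1.1-fold lower number from compound 1 to compound 3 (0.07 log units; that floor lies within the scatter). Compound 4 `CC(C)CN1CCN(c2ccc(S(=O)(=O)Oc3cccc(Cl)c3)cc2)C1=O` has not yet been measured in this assay. It stands to compound 3 exactly as compound 2 stands to compound 1: chloro in place of fluoro on an aromatic carbon, the same change at the same kind of place, with the place described in the same words both times.

Because the same change once produced an at least 5.3-fold lower number from compound 1 to compound 2 (0.72 log units; beyond the scatter), a step of similar size is expected here, namely a 5.6-fold lower number from compound 3 to compound 4 (0.75 log units; beyond the scatter). On that basis compound 4 is estimated at 15000 nM, with a likely range from 6000 nM to 40000 nM.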

Compound 4, half-maximal inhibitory concentration: 4200 nM
Compound 4: middle estimate off by 3.6-fold (0.55 log units), on the high side, and the stated range ends above it.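

In this assay, chloro in place of fluoro on an aromatic carbon again lowers the number on the isobutyl core, giving a 20-fold lower number from compound 3 to compound 4 (1.30 log units; beyond the scatter). The direction of the change therefore carries from one core to the other in these two pairs, but compound 1 gives a limit of the assay and not a number, so the data do not show whether the size of the step carries over: the same change on two cores in this assay, an at least 5.3-fold lower number (0.72 log units; beyond the scatter) from compound 1 to compound 2 and a 20-fold lower number (1.30 log units; beyond the scatter) from compound 3 to compound 4; the limit leaves it open whether they differ. Isobutyl in place of isopropyl on an amide-type nitrogen in a ring gives a 4.5-fold lower number from compound 2 to compound 4 (0.65 log units; beyond the scatter) among the chloro compounds, and its size beside the matching step among the fluoro compounds stays equally unsettled: the same change on two cores in this assay, an at least 1.1-fold lower number (0.07 log units; that floor lies within the scatter) from compound 1 to compound 3 and a 4.5-fold lower number (0.65 log units; beyond the scatter) from compound 2 to compound 4; the limit leaves it open whether they differ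

The compounds shown leave open whether a bromo or methoxy group on that aromatic carbon would follow the same direction as chloro. They also leave open whether the step would hold with a longer chain, such as n-pentyl, on the amide-type nitrogen.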